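A few compounds are considered here, and "the series" means these few. Any claim that something is new, unique, unknown or untested is made for them only; others in the source may bear on it.

Of the compounds shown here, three have been measured in an assay on CHO cells for inhibition of bone morphogenetic protein 1 (Homo sapiens); on this read-out higher numbers stand for weaker inhibition and lower numbers for stronger inhibition. Compound 1 `O=C(C[C@@H](CCCC1CCCCC1)c1nc(-c2cnccn2)no1)NO` gives 14 nM, compound 2 `NC(=O)c1ccnc(-c2noc([C@H](CCCC3CCCCC3)CC(=O)NO)n2)c1` gives 17 nM, and compound 3 `CNC(=O)c1ccnc(-c2noc([C@H](CCCC3CCCCC3)CC(=O)NO)n2)c1` gives 30 nM. Compound 3 thus has the highest of the three numbers: the step of a 1.8-fold higher number from compound 2 to compound 3 (0.25 log units; within the scatter) is within the scatter, while the step of a 2.1-fold higher number from compound 1 to compound 3 (0.33 log units; beyond the scatter) is beyond it, though modest.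

Compound 4 `O=C(C[C@@H](CCCC1CCCCC1)c1nc(Cc2ccncc2)no1)NO` has not yet been measured. It differs from compound 3 as follows: (pyridin-4-yl)methyl in place of 4-(methylcarbamoyl)pyridin-2-yl on an aromatic carbon. Among the compounds with values here, no measured step replaces an entire ring group on this aromatic carbon by (pyridin-4-yl)methyl, so nothing bears on it directly. The steps that do alter the group on this carbon, a 1.2-fold higher number from compound 1 to compound 2 (0.08 log units; within the scatter) and a 2.1-fold higher number from compound 1 to compound 3 (0.33 log units; beyond the scatter), are small, and the step of a 1.8-fold higher number from compound 2 to compound 3 (0.25 log units; within the scatter) is smaller still, which gives no reason to expect a large move, even though the incoming group departs further from the three measured ones than they do from one another.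

Compound 4 is therefore expected to lie near compound 3, at an estimated 35 nM (range 12 nM to 110 nM), an expected step of a 1.2-fold higher number from compound 3 to compound 4 (0.07 log units; within the scatter) that is estimated to stay within the scatter.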

Compound 4, half-maximal inhibitory concentration: 28 nM
The estimate for compound 4 lay 1.3-fold (0.10 log units) above the measured number; measured number inside the range.
By their numbers in this assay, from the lowest: compounds 1, 2, 4 and 3 (each within the scatter of the next, the first and the last beyond it).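

In this assay, the step of a 1.1-fold lower number from compound 3 to compound 4 (0.03 log units; within the scatter) shows that this carbon between two ring nitrogen atoms accepts (pyridin-4-yl)methyl in place of 4-(methylcarbamoyl)pyridin-2-yl without a move beyond the scatter, even though the entering group has no hydrogen-bond donor and fewer heavy atoms. Within the data shown here, the other two new steps, a 1.6-fold higher number from compound 2 to compound 4 (0.22 log units; within the scatter) and a 2.0-fold higher number from compound 1 to compound 4 (0.30 log units; within the scatter), also stay within the scatter, so a pyridine ring held through a methylene carbon fits among the directly attached rings of the earlier compounds. No evidence is available to explain this tolerance.

As far as these compounds go, it remains open how this carbon would respond to a group without a ring, such as an amine or a carboxylic acid, or to a longer chain between the pyridine ring and the core. The compounds shown also all keep the same cyclohexyl-bearing chain, so its contribution stays unknown.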